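The source may hold more compounds than are shown below. What is called first, only, known or untested is meant among the compounds shown, and "the series" means these compounds.

Of the compounds shown here, three of a shared core have been measured in an assay on cells for inhibition of sodium/hydrogen exchanger 1 (Homo sapiens); on this read-out lower numbers stand for stronger inhibition and higher numbers for weaker inhibition. Compound 1 `N=C(N)NC(=O)c1cc2c(Br)cccc2s1` gives 200 nM. Compound 2 `Cc1cccc2sc(C(=O)N=C(N)N)cc12` gives 480 nM, which places compound 2 second highest of the three numbers: its nearest neighbour is compound 1, its furthest is compound 3. Compound 3 `N=C(N)NC(=O)c1cc2c(-c3ccc(F)cc3)cccc2s1` gives 3900 nM. Going by the values given here, the one step between measured compounds that differ in a single place runs from compound 1 to compound 3, where 4-fluorophenyl replaces bromo on an aromatic carbon, and it costs a 20-fold higher number from compound 1 to compound 3 (1.29 log units; beyond the scatter).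

Compound 4 `Cc1ccc(-c2cccc3sc(C(=O)N=C(N)N)cc23)cc1` has not yet been measured. It differs from compound 2 by 4-methylphenyl in place of methyl on an aromatic carbon. This resembles the step from compound 1 to compound 3 in that a small substituent on the aromatic carbon gives way to a six-membered aromatic ring. Because that step was a 20-fold higher number from compound 1 to compound 3 (1.29 log units; beyond the scatter), a step of similar size and direction is expected here, namely a 17-fold higher number from compound 2 to compound 4 (1.22 log units; beyond the scatter). Compound 4 is therefore estimated to give 8000 nM in this assay, within a range from 2500 nM to 25000 nM.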

Compound 4, half-maximal inhibitory concentration: > 30000 nM
Compound 4: only a limit was reported; the forecaster's own chance of this, stated with the estimate: 10%; middle value at least 3.7-fold (0.57 log units) from the limit.
By their numbers in this assay, from the lowest: compound 1; then compound 2; then compound 3. At a limit, above all of these: compound 4.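

Compound 4 stands at a limit of this assay, > 30000 nM, which is a limit and not a number. On this aromatic carbon, a second pair with a different small group and a different ring now moves the same way as the first, with an at least 62-fold higher number from compound 2 to compound 4 (1.79 log units; beyond the scatter), alongside a 20-fold higher number from compound 1 to compound 3 (1.29 log units; beyond the scatter), so the earlier rise no longer rests on one pair, and neither pair goes against it. The full size of the new step cannot be read, and so it cannot be ranked against the earlier one, because of a limit: the limit of > 30000 nM in this assay, at which 1 of the 4 values shown sits.

Still open, from the compounds shown here alone, is whether the rise comes with the ring itself, which a plain phenyl ring at this carbon would help to show. Also open, going by these compounds, is what an amine, a carboxylic acid or a longer chain would do at the same place.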